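Para-substituted benzyl ether on the flavone core: compound 4

A few compounds are considered here, and "the series" means these few. Any claim that something is new, unique, unknown or untested is made for them only; others in the source may bear on it.

Compound 1 `COc1ccc2c(=O)c(-c3cc(OC)c(OC)cc3OC)coc2c1` gives 9400 nM in a functional assay on U-251 cells (Homo sapiens) for antiproliferative activity, read by MTT assay, with a stated time of 24 h (a lower number here means a stronger inhibitor, a higher number a weaker inhibitor), the highest of the two numbers measured. Compound 2 `COc1cc(OC)c(-c2coc3cc(OCc4ccc(Cl)cc4)ccc3c2=O)cc1OC` gives 470 nM, a step of a 20-fold lower number from compound 1 to compound 2 (1.30 log units; beyond the scatter). Compound 3 `COc1cc(OC)c(-c2coc3cc(OCc4ccccc4Br)ccc3c2=O)cc1OC` reaches only the assay limit of > 10000 nM, which is not a number (the limit of > 10000 nM in this assay, at which 1 of the 3 values shown sits). Compound 4 `COc1cc(OC)c(-c2coc3cc(OCc4ccc(C(F)(F)F)cc4)ccc3c2=O)cc1OC` differs from compound 1 by 4-(trifluoromethyl)phenyl in place of hydrogen on a saturated chain carbon bound to an oxygen on an aromatic ring. The change from compound 1 to compound 2 bears most directly on it, as both place a substituent at the same position of the phenyl ring; the change to compound 3 an at least 1.0-fold higher number from compound 1 to compound 3 (0.02 log units; that floor lies within the scatter) shows no gain. A substantial drop in number is therefore expected for compound 4, estimated at a 13-fold lower number from compound 1 to compound 4 (1.13 log units; beyond the scatter), giving 700 nM, with a range from 200 nM to 4000 nM.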

Compound 4, half-maximal inhibitory concentration: 3750 nM
Estimate against measurement, compound 4: 5.4-fold (0.73 log units) below, and the stated range covers the measured number.
By their numbers in this assay, from the lowest: compound 2; then compound 4; then compound 1. At a limit, above all of these: compound 3.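

The step to 4-(trifluoromethyl)benzyl gives a 2.5-fold lower number from compound 1 to compound 4 (0.40 log units; beyond the scatter), so a gain over the methyl ether remains. Trifluoromethyl in place of chloro on an aromatic carbon, however, gives an 8.0-fold higher number from compound 2 to compound 4 (0.90 log units; beyond the scatter), which shows that the group on that carbon sets how much is gained. Replacing 2-bromophenyl gives an at least 2.6-fold lower number from compound 3 to compound 4 (0.42 log units; beyond the scatter), a step that starts from a limit of the assay, not a number: the limit of > 10000 nM in this assay, at which 1 of the 4 values shown sits.

From the compounds shown here alone, how an amine or a carboxylic acid on that aromatic carbon would read stays open, as does the effect of a longer chain on the ether oxygen.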